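This account rests on a few compounds, and the source may have more. Where it says the series, first, only, none or still open, it means among the compounds named here.

Compound 1 `COc1ccccc1/C=C/S(=O)(=O)Cc1ccc(OC)c([N+](=O)[O-])c1`: 20000 nM
Compound 2 `COc1ccc(CS(=O)(=O)/C=C/c2cc(F)c(F)cc2F)cc1N`: 5000 nM
Compound 3 `COc1ccc(/C=C/S(=O)(=O)Cc2ccc(OC)c([N+](=O)[O-])c2)cc1`: 25000 nM

In a functional assay on DU-145 cells (Homo sapiens) for cytotoxicity, read by trypan blue exclusion, with a stated time of 96 h (on this read-out higher numbers stand for weaker inhibition and lower numbers for stronger inhibition), compound 3 gives 25000 nM. That lies within the scatter of compound 1, while compound 2 gives a clearly lower number at 5000 nM. The next compound to consider, compound 4 `COc1ccc(/C=C/S(=O)(=O)Cc2ccc(OC)c(N)c2)cc1`, has amino in place of nitro on an aromatic carbon, ortho to a methoxy group (amino in place of nitro on an aromatic carbon). Among the compounds with values here, no measured step makes this swap directly. Within the data shown here, the one measured step, a 1.3-fold higher number from compound 1 to compound 3 (0.10 log units; within the scatter), exchanges 2-methoxyphenyl for 4-methoxyphenyl and leaves the nitro group in place, so it says little here. Among the measured compounds shown here, the only measured compound with an amino group is compound 2, at 5000 nM, but it also differs from compound 3 on its other ring, so this is a hint and not a clean comparison. On that hint, a move towards a lower number, meaning stronger inhibition, is expected, and the expected step is a 4.2-fold lower number from compound 3 to compound 4 (0.62 log units; beyond the scatter). For compound 4 the estimate is 6000 nM, with an expected range from 1500 nM to 20000 nM.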

Compound 4, half-maximal inhibitory concentration: 2500 nM
The estimate for compound 4 lay 2.4-fold (0.38 log units) above the measured number; the measured number falls inside the stated range.
By their numbers in this assay, from the lowest: compounds 4 and 2 (each within the scatter of the next); then compounds 1 and 3 (each within the scatter of the next).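

In this assay, replacing nitro with amino on this aromatic carbon, ortho to a methoxy group, gives a 10-fold lower number from compound 3 to compound 4 (1.00 log units; beyond the scatter), a direct reading of this swap with the rest of the molecule unchanged. Unlike the only earlier step, which stayed within the scatter, this single change moves the number beyond it, although the swap changes several things at once: the heavy-atom count falls and a hydrogen-bond donor enters. No measurement shown explains the difference or separates these features.

From the compounds shown here alone, it remains open whether the same swap would have a similar effect with the 2-methoxyphenyl group of compound 1 on the other side of the molecule. Going by these compounds, how a hydroxyl group or an acetamide would compare with amino at this position also remains open.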